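The compounds below may be only part of what the source reports. "The series", "measured", "known", "first", "only" and "open" are said of these compounds alone.

Measured so far in a functional assay on Shh Light II cells (Mus musculus) for inhibition, read by a luciferase reporter; on this read-out lower numbers stand for stronger inhibition and higher numbers for weaker inhibition:
compound 1 `N#Cc1ccccc1NC(=O)N1CCC(c2nc(-c3ccc4ccccc4n3)no2)CC1` — 190 nM
compound 2 `COc1ccccc1NC(=O)N1CCC(c2noc(-c3ccc4ccccc4n3)n2)CC1` — 2400 nM
compound 3 `Cn1c(-c2noc(C3CCN(C(=O)NC4CCCCC4)CC3)n2)nc2ccccc21` — 89 nM

Compound 1 holds the second highest of the three numbers. Its nearest neighbour is compound 3, which in this assay gives 89 nM, a gap beyond the usual scatter; its furthest is compound 2, which gives 2400 nM, a gap far beyond the scatter. No two of these compounds differ in one place only, so no single-point step exists to calibrate the change now in hand.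

Compound 4 `O=C(Nc1cccnc1Cl)N1CCC(c2nc(-c3ccc4ccccc4n3)no2)CC1` is not yet measured. It differs from compound 1 in this way: 2-chloropyridin-3-yl in place of 2-cyanophenyl on an amide-type nitrogen. Among the measured compounds shown here, no measured pair carries this or a related exchange on the amide-type nitrogen, so neither direction nor size can be read from the set; the data only show that different groups at this position can sit across a wide span of values. The expected step, a 1.4-fold higher number from compound 1 to compound 4 (0.14 log units; within the scatter), is small, probably within the scatter, with a lean toward a slightly higher number. Compound 4 is therefore expected at 260 nM, within a range of 80 nM to 850 nM.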

Compound 4, half-maximal inhibitory concentration: 1600 nM
Estimate against measurement, compound 4: 6.2-fold (0.79 log units) below, outside the stated range (above it).
By their numbers in this assay, from the lowest: compound 3; then compound 1; then compounds 4 and 2 (each within the scatter of the next).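

On this assay the group on the amide-type nitrogen is far from interchangeable: 2-chloropyridin-3-yl in place of 2-cyanophenyl gives an 8.4-fold higher number from compound 1 to compound 4 (0.93 log units; beyond the scatter) and so weaker inhibition. Among the compounds shown here, this is the first single-place step, so the sensitivity of this position now rests on a direct comparison with the rest of the compound held constant. No measurement on hand accounts for the size or direction of this step.

On these data alone, the exchange alters the nitrile, the chlorine and the ring nitrogen together, so the share of each remains open. Plain phenyl and 2-chlorophenyl on the same amide-type nitrogen would help to separate these contributions, and it also remains open whether the step carries over to other cores in the series.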